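Shortening the sulfonyl chain: an expected lipophilicity step

This account rests on a few compounds, and the source may have more. Where it says the series, first, only, none or still open, it means among the compounds named here.

Of the compounds shown here, three built on a shared core have been measured in a physicochemical assay for lipophilicity; a higher number here means a more lipophilic compound, a lower number a more polar compound. Compound 3 `CC(C)(c1cc([C@]23CCOC[C@H]2C3)nc(-c2cccc(O)c2)n1)S(C)(=O)=O` gives 4.8. Compound 1 `CS(=O)(=O)Cc1cc([C@]23CCOC[C@H]2C3)nc(-c2cccc(O)c2)n1` gives 3.7. The two differ by (methylsulfonyl)methyl in place of 1-methyl-1-(methylsulfonyl)ethyl on an aromatic carbon, and the measured step is a number 1.10 log units lower from compound 3 to compound 1 (beyond the scatter). Compound 2 `CNCC(=O)Nc1ccc(-c2nc(C(C)(C)S(C)(=O)=O)cc([C@]34CCOC[C@H]3C4)n2)cc1` gives 4.3; how its core differs from that of compound 3 is not broken down here.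

Compound 4 `CNCC(=O)Nc1ccc(-c2nc(CS(C)(=O)=O)cc([C@]34CCOC[C@H]3C4)n2)cc1` has not yet been measured in this assay. Against compound 2 it shows ((methylsulfonyl)methyl in place of 1-methyl-1-(methylsulfonyl)ethyl on an aromatic carbon). This is the same kind of change as from compound 3 to compound 1, though the surroundings differ: in compound 3 the place is meta to a 3-hydroxyphenyl group (7 heavy atoms), whereas in compound 2 it is meta to a large group. Because the measured change was a number 1.10 log units lower from compound 3 to compound 1 (beyond the scatter), a step of a number 1.10 log units lower from compound 2 to compound 4 (beyond the scatter) is expected. Compound 4 is therefore estimated to show 3.2.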

Compound 4, partition coefficient: 3.1
Estimate against measurement, compound 4: 0.10 log units above, within the range that was stated.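

In this assay, putting (methylsulfonyl)methyl in place of 1-methyl-1-(methylsulfonyl)ethyl gives a number 1.20 log units lower from compound 2 to compound 4 (beyond the scatter) on one core and a number 1.10 log units lower from compound 3 to compound 1 (beyond the scatter) on the other, so the step is large and runs the same way in both pairs. Among the compounds shown here, this shows that the change carried over between these two cores, but with only two pairs it does not show that the step would hold on any other core. Nothing available here explains the size of the step.

The compounds shown leave open how the number moves with a longer chain, such as 2-(methylsulfonyl)ethyl, in the same place. They also leave open whether the step holds when a carboxylic acid replaces the hydroxyl of the 3-hydroxyphenyl group.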